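The source may report more compounds than this note shows. Statements on the series, on what has been measured and on what is new or still open speak of the compounds shown alone.

Compound 1 `CC1CCCCC1N(CCCCCCN1C[C@H](O)[C@@H](O)[C@H](O)[C@H]1CO)C(=O)C(C)(C)C` in an ADME assay on MDBK cells (Bos taurus) for cytotoxicity, read by MTT assay (a higher number here means that more compound is tolerated, a lower number that less compound is tolerated), gives > 500000 nM, a limit of the assay. Compound 2 `CC(C)(C)C(=O)N(CCCCCCN1C[C@H](O)[C@@H](O)[C@H](O)[C@H]1CO)c1cc(F)ccc1F` in this assay gives > 500000 nM, likewise a limit. Compound 3 `CC(=O)N(CCCCCCN1C[C@H](O)[C@@H](O)[C@H](O)[C@H]1CO)c1cc(F)ccc1F` in this assay gives > 500000 nM, again a limit.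

Compound 2 therefore stands only at a limit, as do its two neighbours, because of the limit of > 500000 nM in this assay, at which 3 of the 3 values shown sit. The step that the two limits leave unreadable from compound 1 to compound 2 and the step that the two limits leave unreadable from compound 2 to compound 3 are both unreadable. Compound 4 `CC(C)(C)C(=O)N(CCCCCCN1C[C@H](O)[C@@H](O)[C@H](O)[C@H]1CO)C1CCCC1` differs from compound 2 by cyclopentyl in place of 2,5-difluorophenyl on an amide-type nitrogen. The step from compound 1 to compound 2 also exchanges the group on the amide-type nitrogen, yet it tells nothing of size. Compound 4 is thus expected to sit at the same limit, an estimate of 500000 nM ranging from 250000 nM to 1000000 nM. The expected step is a number no higher from compound 2 to compound 4 (the limit leaves the size open).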

Compound 4, half-maximal cytotoxic concentration: > 500000 nM
Compound 4: a limit, no number; the forecaster's own chance of this, stated with the estimate: 85%; the middle value lies on the limit itself.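

Within the data shown here, compound 4 gives > 500000 nM in this assay, a limit of the assay, and no step between it and compound 1 or compound 2 can be read. The compounds shown leave open whether the group on the amide-type nitrogen changes how much compound is tolerated: the limit of > 500000 nM in this assay, at which 4 of the 4 values shown sit.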